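A few compounds are considered here, and "the series" means these few. Any claim that something is new, unique, unknown or untested is made for them only; others in the source may bear on it.

Compounds measured in a functional assay on SW480 cells (Homo sapiens) for antiproliferative activity, read by MTT assay, with a stated time of 48 h; a lower number here means a stronger inhibitor, a higher number a weaker inhibitor
- compound 1 `CCN(CC)C/C1=C/C[C@](C)(CCC=C(C)C)/C=C/[C@@H](OC(=O)C=C(C)C)[C@](C)(O)/C=C/C1=O` gives 270 nM
- compound 2 `CSC(=S)OC/C1=C/C[C@](C)(CCC=C(C)C)/C=C/[C@@H](OC(=O)C=C(C)C)[C@](C)(O)/C=C/C1=O` gives 390 nM

Compound 2 (390 nM) and compound 1 (270 nM) lie within the scatter of each other, so the two cannot be ranked. Compound 3 `CC(C)=CCC[C@]1(C)/C=C/[C@@H](OC(=O)C=C(C)C)[C@](C)(O)/C=C/C(=O)/C(C(=O)N(C)C)=C\C1` has not yet been measured. It differs from compound 2 on a double-bonded ring carbon, where a dimethylcarbamoyl enters (a group of 5 heavy atoms (3 carbon, 1 nitrogen, 1 oxygen; no ring) in place of a group of 6 heavy atoms (3 carbon, 1 oxygen, 2 sulfur; no ring), on a double-bonded ring carbon).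

Within the data shown here, only one measured step bears on this change, a 1.4-fold higher number from compound 1 to compound 2 (0.16 log units; within the scatter), and it stayed within the scatter. That step exchanged groups on a saturated chain carbon bound to a double-bonded ring carbon. Among the measured compounds shown here, in compound 3, the dimethylcarbamoyl stands on the double-bonded ring carbon itself, and no measured compound carries a group placed that way. The evidence is therefore thin. No shift beyond the scatter is expected in this assay, and no direction can be favoured, though the uncertainty is wide. The expected change is a 1.2-fold higher number from compound 2 to compound 3 (0.06 log units; within the scatter), which is only an estimate. Compound 3 is estimated at 450 nM (expected range 150 nM to 1500 nM).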

Compound 3, half-maximal inhibitory concentration: 3300 nM
Compound 3: the middle estimate sits 7.3-fold (0.87 log units) below what was measured; measured number above the stated range.
By their numbers in this assay, from the lowest: compounds 1 and 2 (each within the scatter of the next); then compound 3.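

In this assay the double-bonded ring carbon proves sensitive to what it carries, a sensitivity the earlier pair could not reveal, since its exchange on the saturated chain carbon stayed within the scatter. Setting dimethylcarbamoyl directly on that ring carbon gives an 8.5-fold higher number from compound 2 to compound 3 (0.93 log units; beyond the scatter) and, in place of (diethylamino)methyl, a 12-fold higher number from compound 1 to compound 3 (1.09 log units; beyond the scatter), so both steps point the same way, and the only compound with the carbonyl of the new group on the ring carbon has the highest number of the three. Nothing available accounts for the size of these steps.

With a single group of this kind, the change of group cannot be separated from the loss of the saturated chain carbon that compound 1 and compound 2 share. A dimethylcarbamoylmethyl group would test that directly, while a carboxylic acid or a methyl ester on the same ring carbon would show whether the rise extends beyond this one amide.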